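This account rests on a few compounds, and the source may have more. Where it says the series, first, only, none or still open, it means among the compounds named here.

For the measured compounds named here, compound 2 `COc1cccc(Oc2ccc3c(NCCCNCc4cc(F)ccc4OC)ccnc3c2)c1` is one of three compounds so far measured in an ADME assay for permeability, using PAMPA, with a stated time of 30 min, at pH 7.4; a lower number here means that the compound crosses the layer more slowly, a higher number that the compound crosses the layer faster. Compound 2 gives 317 10^-6 cm/s, level with compound 3 `COc1cccc(Oc2ccc3c(NCCCNCc4cccc(OC)c4O)ccnc3c2)c1`, which gives 317 10^-6 cm/s; together they are the highest of the three numbers, and the step of no change at the digits printed from compound 2 to compound 3 (within the scatter) shows that swapping the aryl group on the chain made no difference beyond the scatter. Compound 1 `Fc1ccc(-c2ccc3c(NCCCNCc4ccco4)ccnc3c2)cc1` gives 237 10^-6 cm/s, and the gap between compound 1 and compound 2 also lies within the scatter, so the three numbers form a narrow band.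

Compound 4 `COc1ccc(F)cc1CNCCCNc1ccnc2cc(-c3ccccc3)ccc12` has not yet been measured. Set against compound 2, the change is phenyl in place of 3-methoxyphenoxy on an aromatic carbon. Going by the values given here, no measured pair differs in exactly this way. Among the compounds with values here, the one step measured, no change at the digits printed from compound 2 to compound 3 (within the scatter), touches the chain and not the core, and it was flat; compound 1, whose core carries a simple aryl ring at the same position, gave a number close to that of compound 2. With every measured compound crossing the layer at a similar rate, no step beyond the scatter is expected here. Compound 4 is therefore expected to give 270 10^-6 cm/s, with a likely range from 150 10^-6 cm/s to 450 10^-6 cm/s. The expected step is a 1.2-fold lower number from compound 2 to compound 4 (0.07 log units; within the scatter).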

Compound 4, apparent permeability: 237 10^-6 cm/s
Compound 4: the middle estimate sits 1.1-fold (0.06 log units) above what was measured; low and high end bracket the measured number.
By their numbers in this assay, from the lowest: compounds 1, 4, 2 and 3 (each within the scatter of the next).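

In this assay, for the compounds shown here, putting phenyl in place of 3-methoxyphenoxy gives a 1.3-fold lower number from compound 2 to compound 4 (0.13 log units; within the scatter), the first measured change at this aromatic carbon of the shared core rather than on the chain. The earlier step altered only the aryl group on the chain, so this result adds that the group on the core can also be exchanged without a change beyond the scatter. The exchange is not a small one on paper: 3-methoxyphenoxy has 9 heavy atoms and 2 hydrogen-bond acceptors, whereas phenyl has 6 heavy atoms and no hydrogen-bond acceptors, yet the read-out stays within the same narrow band. No supporting data are available to explain why the number holds steady.

On these data alone, the two groups compared here each contain a six-membered aromatic ring of carbon only and carry no net charge, so it remains open whether a carboxylic acid or an amine on this carbon would stay in the same band. As far as these compounds go, it also remains open whether a longer chain joining the core to the benzylamine nitrogen would leave the number unchanged.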